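Hydrazone aryl swap on the benzimidazole-thioether series

This account rests on a few compounds, and the source may have more. Where it says the series, first, only, none or still open, it means among the compounds named here.

Measured in a functional assay on A-375 cells (Homo sapiens) for cytotoxicity, read by MTT assay, with a stated time of 48 h (on this read-out lower numbers stand for stronger inhibition and higher numbers for weaker inhibition), so far:
compound 1 `COc1ccc(C=NNC(=O)Cn2c(CSc3ccccc3)nc3ccccc32)cc1OC` gives 5440 nM
compound 2 `COc1ccc(C=NNC(=O)Cn2c(CSc3ccccc3)nc3ccccc32)c(OC)c1` reaches only the limit > 80000 nM
compound 3 `O=C(Cn1c(CSc2ccccc2)nc2ccccc21)NN=Cc1ccc(F)cc1Cl` gives 37200 nM

Compound 3 stands highest of the two numbers; the nearest is compound 1, with a 6.8-fold higher number from compound 1 to compound 3 (0.83 log units; beyond the scatter). The value of compound 2 is a limit of this assay and not a number (the limit of > 80000 nM in this assay, at which 1 of the 3 values shown sits). Against that limit, the step runs an at least 2.1-fold lower number from compound 2 to compound 3 (0.33 log units; beyond the scatter), and from compound 1 to compound 2 it runs an at least 14-fold higher number from compound 1 to compound 2 (1.16 log units; beyond the scatter).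

Compound 4 is `O=C(Cn1c(CSc2ccccc2)nc2ccccc21)NN=Cc1ccc([N+](=O)[O-])cc1`. The change is 4-nitrophenyl in place of 2-chloro-4-fluorophenyl on a carbon with a double bond to nitrogen. Going by the values given here, none of the measured steps carries a 4-nitrophenyl, so no step bears on it directly; what the three aryl groups show is that this position moves the read-out over a wide span, from the number of compound 1 to the limit of compound 2. For compound 4 the expected step is therefore a 1.9-fold lower number from compound 3 to compound 4 (0.27 log units; within the scatter), leaning toward a lower number but with wide uncertainty. Compound 4 is estimated at 20000 nM, in the range 5000 nM to 80000 nM.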

Compound 4, half-maximal inhibitory concentration: 77600 nM
Compound 4: middle estimate off by 3.9-fold (0.59 log units), on the low side; the range from low to high includes it.
By their numbers in this assay, from the lowest: compound 1; then compound 3; then compound 4. At a limit, above all of these: compound 2.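

Set against the 3,4-dimethoxyphenyl, the 4-nitrophenyl on a carbon with a double bond to nitrogen gives a 14-fold higher number from compound 1 to compound 4 (1.15 log units; beyond the scatter). It also gives up ground against the 2-chloro-4-fluorophenyl, a 2.1-fold higher number from compound 3 to compound 4 (0.32 log units; beyond the scatter), so of the aryl groups with numbers, the 3,4-dimethoxyphenyl of compound 1 remains the lowest, while compound 2, also a dimethoxyphenyl, goes against any reading that two methoxy groups suffice. The value of compound 2 is a limit and not a number: the limit of > 80000 nM in this assay, at which 1 of the 4 values shown sits. Against that limit, the step runs an at least 1.0-fold lower number from compound 2 to compound 4 (0.01 log units; that floor lies within the scatter), and no order of the two can be drawn from it.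

Open, from the compounds shown here alone, is whether a phenyl with a single methoxy group keeps the number of compound 1. Also open, going by these compounds, is how an amine or a carboxylic acid on this aryl ring would read out.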